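Cytotoxicity series: piperazin-1-yl replaces 3-fluorophenyl on the core

The source may hold more compounds than are shown below. What is called first, only, known or untested is meant among the compounds shown, and "the series" means these compounds.

Measured in an ADME assay on THP-1 cells (Homo sapiens) for cytotoxicity, read by MTT assay, with a stated time of 72 h (a lower number here means that less compound is needed, a higher number that more compound is needed for the effect), every value so far is a limit of the assay rather than a number:
compound 1 `O=c1nc(-c2ccccc2)c2cc(-c3cccc(F)c3)ccc2[nH]1` gives > 50000 nM.
compound 2 `CNC(=O)c1cccc(-c2ccc3[nH]c(=O)nc(-c4ccccc4)c3c2)c1` gives > 50000 nM.
compound 3 `O=c1nc(-c2ccccc2)c2ccc(-c3ccc(F)cc3)cc2[nH]1` gives > 50000 nM.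

Compound 1 therefore stands only at a limit, as do the other two: the limit of > 50000 nM in this assay, at which 3 of the 3 values shown sit. Within the data shown here, the single measured step, a step that the two limits leave unreadable from compound 1 to compound 2, runs between two limits and its size cannot be read, so no measured step bears on the change now at hand.

Compound 4 `O=c1nc(-c2ccccc2)c2cc(N3CCNCC3)ccc2[nH]1` differs from compound 1 in one place: piperazin-1-yl in place of 3-fluorophenyl on an aromatic carbon.

With nothing readable to lean on, compound 4 is expected to stay at the limit as well. The estimate for compound 4 is 50000 nM, range 20000 nM to 100000 nM. The step of a number no higher from compound 1 to compound 4 (the limit leaves the size open) is expected to be none beyond the scatter, a limit being the most probable outcome.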

Compound 4, half-maximal effective concentration: > 25000 nM
Compound 4: no number, only a limit (the forecaster's own chance of this, stated with the estimate: 75%); the middle value is on the limit's open side.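

Compound 4 gives > 25000 nM, a limit of the assay. Among these compounds, compound 1 gives > 50000 nM, also a limit, so no step to compound 4 can be read. As far as these compounds go, whether piperazin-1-yl shifts cytotoxicity relative to 3-fluorophenyl stays open.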